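Cyclopropyl acid stereochemistry in the phenoxybenzylamine series

The source may hold more compounds than are shown below. What is called first, only, known or untested is meant among the compounds shown, and "the series" means these compounds.

Compound 1 `O=C(O)/C=C/c1ccc(NCc2cccc(Oc3ccccc3)c2)cc1`: 145 nM
Compound 2 `O=C(O)[C@H]1C[C@@H]1c1ccc(NCc2cccc(Oc3ccccc3)c2)cc1`: 12.3 nM; 13.5 nM (2 entries)
Compound 3 `CC(CC(=O)O)c1ccc(NCc2cccc(Oc3ccccc3)c2)cc1`: 126 nM

In a functional assay on CHO cells for agonist activity at Free fatty acid receptor 1 (Homo sapiens) (a higher number here means that more compound is needed for the effect, a lower number that less compound is needed), compound 3 sits lowest of the two single numbers, with compound 1 close by; the step of a 1.2-fold lower number from compound 1 to compound 3 (0.06 log units; within the scatter) is within the scatter. Compound 4 `O=C(O)[C@@H]1C[C@H]1c1ccc(NCc2cccc(Oc3ccccc3)c2)cc1` differs from compound 3 by 2-carboxycyclopropyl in place of 1-(carboxymethyl)ethyl on an aromatic carbon. For the measured compounds named here, no measured step carries this change directly. Going by the values given here, the only bearing comes from compound 2, which holds the same 2-carboxycyclopropyl group with the opposite defined stereocentres and gives the lowest numbers of the set (the several entries of compound 2 in this assay, 12.3 nM; 13.5 nM (2 entries)). Whether the other stereoisomer shares that lies open; a step back toward compound 3 or weaker is expected rather than the gain seen for compound 2. Compound 4 is therefore estimated at 150 nM, within 30 nM to 800 nM, a step of a 1.2-fold higher number from compound 3 to compound 4 (0.08 log units; within the scatter) expected.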

Compound 4, half-maximal effective concentration: 562 nM
For compound 4 the middle estimate is 3.7-fold (0.57 log units) below the measured one; the range from low to high includes it.
By their numbers in this assay, from the lowest: compounds 3 and 1 (each within the scatter of the next); then compound 4.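

In this assay, a change of a 4.5-fold higher number from compound 3 to compound 4 (0.65 log units; beyond the scatter) and one of a 3.9-fold higher number from compound 1 to compound 4 (0.59 log units; beyond the scatter) show that 2-carboxycyclopropyl at this position does not by itself give low numbers. For the compounds shown here, the printed values of compound 2 stand well below compound 4 at 562 nM in this series, so the outcome with this group depends on its stereocentres, the only point separating the pair: the fact that compounds 2 and 4 differ only in the configuration as drawn.

Still open, from the compounds shown here alone, is whether the same dependence on configuration holds with a tetrazole in place of the carboxylic acid. Also open, going by these compounds, is how a methyl group on the cyclopropane ring would affect either stereoisomer.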